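The compounds below may be only part of what the source reports. "The series", "measured", "known", "first", "only" and "open" are said of these compounds alone.

For the measured compounds named here, compound 3 `COc1ccc(F)c([C@H]2CC[C@H](COc3cccc([C@H](C4CC4)[C@](C)(F)C(=O)O)c3)CC2)c1` gives 6.9 nM in a functional assay on HEK293 cells for agonist activity at Free fatty acid receptor 1 (Rattus norvegicus), read by FLIPR and calcium flux (on this read-out higher numbers stand for an effect only at larger amounts of compound and lower numbers for an effect already at smaller amounts), and stands highest of the three numbers measured so far. Its nearest neighbour is compound 1 `COc1ccc(F)c([C@H]2CC[C@H](COc3cccc([C@H](C4CC4)[C@@H](C)C(=O)O)c3)CC2)c1`, which in this assay gives 4.9 nM; the step of a 1.4-fold higher number from compound 1 to compound 3 (0.15 log units; within the scatter) stays within the scatter. Compound 2 `COc1ccc(F)c([C@H]2CC[C@H](COc3cccc([C@H](C4CC4)[C@@](C)(F)C(=O)O)c3)CC2)c1` gives 0.34 nM in this assay, and the step of a 20-fold higher number from compound 2 to compound 3 (1.31 log units; beyond the scatter) is large, a difference that rests on (the fact that compounds 2 and 3 differ only in the configuration as drawn). The step of a 14-fold lower number from compound 1 to compound 2 (1.16 log units; beyond the scatter) is likewise large.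

The next change is 1-carboxy-1-methylethyl in place of 1-carboxy-1-fluoroethyl on a saturated chain carbon bound to an aromatic carbon and a saturated ring carbon, giving compound 4 `COc1ccc(F)c([C@H]2CC[C@H](COc3cccc([C@H](C4CC4)C(C)(C)C(=O)O)c3)CC2)c1`. Going by the values given here, none of the measured steps replaces fluorine by methyl at this place; the only measured steps touching this group are the fluoro-for-hydrogen step and the configuration step, and the change to compound 4 removes the stereocentre that separates compound 2 from compound 3. Compound 4 is therefore expected to fall close to compound 1 and compound 3 rather than to compound 2. The step of a 1.4-fold lower number from compound 3 to compound 4 (0.14 log units; within the scatter) is expected to stay within or near the scatter. For compound 4 the estimate in this assay is 5 nM, with a range from 1.5 nM to 20 nM.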

Compound 4, half-maximal effective concentration: 0.31 nM
Compound 4: the middle estimate sits 16-fold (1.21 log units) above what was measured, outside the stated range (below it).
By their numbers in this assay, from the lowest: compounds 4 and 2 (each within the scatter of the next); then compounds 1 and 3 (each within the scatter of the next).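

In this assay, 1-carboxy-1-methylethyl on a saturated chain carbon bound to an aromatic carbon and a saturated ring carbon gives a 16-fold lower number from compound 1 to compound 4 (1.20 log units; beyond the scatter) and a 22-fold lower number from compound 3 to compound 4 (1.35 log units; beyond the scatter) so replacing the remaining hydrogen of compound 1 can pay off without fluoro and without a defined stereocentre at that carbon. The step of a 1.1-fold lower number from compound 2 to compound 4 (0.04 log units; within the scatter) places compound 4 level with the better fluoro compound, whereas compound 3 goes against any general gain from a second group there. What separates the two fluoro compounds remains a matter of one stereocentre: the fact that compounds 2 and 3 differ only in the configuration as drawn.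

The compounds shown leave open whether ethyl or hydroxyl at this carbon would fit the same pattern. They also leave open what makes methyl match the fluoro of compound 2 but not that of compound 3.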